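Naphthalene in place of quinoline at the amide carbonyl

This account rests on a few compounds, and the source may have more. Where it says the series, first, only, none or still open, it means among the compounds named here.

Three guanidine-bearing amides share one core. Compound 1 `N=C(N)NCCC[C@@H](NC(=O)c1cnc2ccccc2c1)C(=O)NCc1ccc(C(F)(F)F)cc1` gives 96 nM in a functional assay on HEK293 cells for antagonist activity at melanin-concentrating hormone receptor 1 (Homo sapiens); on this read-out higher numbers stand for weaker inhibition and lower numbers for stronger inhibition; compound 2 `N=C(N)NCCC[C@@H](NC(=O)c1ccc(F)c2ccccc12)C(=O)NCc1ccc(C(F)(F)F)cc1` gives 311 nM; compound 3 `N=C(N)NCCC[C@@H](NC(=O)c1ccnc2ccccc12)C(=O)NCc1ccc(C(F)(F)F)cc1` gives 1030 nM, the highest number of the three, with an 11-fold higher number from compound 1 to compound 3 (1.03 log units; beyond the scatter) and a 3.3-fold higher number from compound 2 to compound 3 (0.52 log units; beyond the scatter). Compound 4 `N=C(N)NCCC[C@@H](NC(=O)c1ccc2ccccc2c1)C(=O)NCc1ccc(C(F)(F)F)cc1` carries naphthalen-2-yl in place of quinolin-4-yl on a carbonyl carbon. The relevant measured steps are a 3.3-fold higher number from compound 2 to compound 3 (0.52 log units; beyond the scatter) and an 11-fold higher number from compound 1 to compound 3 (1.03 log units; beyond the scatter), both beyond the scatter, and both run in the direction of compound 3 being the weakest. Undoing the quinolin-4-yl is therefore expected to lower the number; a step of about a 4.7-fold lower number from compound 3 to compound 4 (0.67 log units; beyond the scatter) is estimated, because compound 2 with its naphthalene gave 311 nM. Compound 4 is expected to give 220 nM, within 70 nM to 700 nM.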

Compound 4, half-maximal inhibitory concentration: 212 nM
Estimate against measurement, compound 4: 1.0-fold (0.02 log units) above, and the stated range covers the measured number.
By their numbers in this assay, from the lowest: compound 1; then compounds 4 and 2 (each within the scatter of the next); then compound 3.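

Carbon-only naphthalen-2-yl on this carbonyl carbon improves on quinolin-4-yl, with a 4.9-fold lower number from compound 3 to compound 4 (0.69 log units; beyond the scatter), yet it does not match quinolin-3-yl, with a 2.2-fold higher number from compound 1 to compound 4 (0.34 log units; beyond the scatter). Against the other carbon-only group, 4-fluoronaphthalen-1-yl, the change stays inside the scatter, at a 1.5-fold lower number from compound 2 to compound 4 (0.17 log units; within the scatter), so these two groups cannot be told apart here. The two quinolines fall on either side of that pair, so a ring nitrogen alone sets no single direction at this position.

Whether an amine or a methoxy group on the naphthalen-2-yl would shift the number remains open, and nothing here gives a reason for these differences.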